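The source may report more compounds than this note shows. Statements on the series, on what has been measured and on what is new or still open speak of the compounds shown alone.

Compound 2 `Cc1cc(NC(=O)Nc2ccc(O)cc2)c2ccccc2n1` shares its core with compound 1 `Cc1cc(NC(=O)Nc2cccc(Cl)c2)c2ccccc2n1` and differs from it only by the group carried on the amide-type nitrogen. In an ADME assay on BJ cells (Homo sapiens) for cytotoxicity, with a stated time of 72 h (a lower number here means that less compound is needed, a higher number that more compound is needed for the effect), compound 1 gives > 25000 nM, which is a limit of the assay rather than a number. In this assay compound 2 likewise gives > 25000 nM, again only a limit. The step that the two limits leave unreadable from compound 1 to compound 2 therefore stays unreadable, as the limit of > 25000 nM in this assay, at which 2 of the 2 values shown sit, shows. Compound 3 `CCc1ccc(NC(=O)Nc2cc(C)nc3ccccc23)cc1` carries ethyl in place of hydroxy on an aromatic carbon. Among the measured compounds shown here, no measured step bears on this change, and the one comparable pair rests on two limits, so no step beyond the scatter is expected in this assay. The expected step is a step that the limit leaves unreadable from compound 2 to compound 3. Compound 3 is estimated to give 30000 nM, within 10000 nM to 100000 nM, most probably reported once more only as a limit.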

Compound 3, half-maximal effective concentration: > 25000 nM
Compound 3 gave a limit, no number; the forecaster's own chance of this, stated with the estimate: 80%; the middle value is on the limit's open side.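

Among the compounds shown here, compound 2 and compound 3 both give only a limit and no number, so no step between them can be read: the limit of > 25000 nM in this assay, at which 3 of the 3 values shown sit. The compounds shown leave open whether any group at this place would give a measured number rather than a limit.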